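Series notes: meta-substituted aryl cyclohexenyl esters at the dopamine transporter

A few compounds are considered here, and "the series" means these few. Any claim that something is new, unique, unknown or untested is made for them only; others in the source may bear on it.

Measured so far:
compound 1 `COC(=O)C1=C(c2cccc(N)c2)CCC1` — 875000 nM
compound 2 `COC(=O)C1=C(c2cccc(Cl)c2)CCCC1` — 22000 nM

In an assay on COS-1 cells for displacement of a labelled ligand from sodium-dependent dopamine transporter (Homo sapiens) (on this read-out higher numbers stand for weaker inhibition and lower numbers for stronger inhibition), compound 2 gives the lowest number of the two; compound 1 gives a number far higher, well beyond the scatter. The next step goes to compound 3 `COC(=O)C1=C(c2ccccc2)CCCC1`, not yet measured: hydrogen in place of chloro on an aromatic carbon. Within the data shown here, no step between measured compounds bears on this change, so the expectation rests on compound 2 alone. A moderate move toward weaker inhibition is expected, estimated as a 3.2-fold higher number from compound 2 to compound 3 (0.50 log units; beyond the scatter). Compound 3 is expected at about 70000 nM, within 25000 nM to 250000 nM.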

Compound 3, inhibition constant: 630000 nM
The estimate for compound 3 lay 9.0-fold (0.95 log units) below the measured number; measured number above the stated range.
By their numbers in this assay, from the lowest: compound 2; then compounds 3 and 1 (each within the scatter of the next).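

In this assay, hydrogen in place of chloro on an aromatic carbon, meta to a large group, gives a 29-fold higher number from compound 2 to compound 3 (1.46 log units; beyond the scatter) and so shows that inhibition on this core depends strongly on what occupies this position. The chloro accounts for a large step, and compound 2 keeps the stronger inhibition of the pair. Nothing available explains the size of this step. Open, going by these compounds, is whether fluoro, methoxy or trifluoromethyl at this position would match chloro. Also open, on these data alone, is whether chloro elsewhere on the aromatic ring would give a similar step.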